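Acrylhydroxamate in Place of Benzohydroxamate on a Triazole Core

This account rests on a few compounds, and the source may have more. Where it says the series, first, only, none or still open, it means among the compounds named here.

Measured so far:
compound 1, `O=C(NO)c1cccc(-c2cn([C@H]3C[C@H](C(=O)O)N(Cc4ccccc4)C3)nn2)c1`, < 10%
compound 2, `O=C(/C=C/c1cn([C@@H]2C[C@@H](CO)N(Cc3ccccc3)C2)nn1)NO`, < 10%
compound 3, `O=C(NO)c1cccc(-c2cn([C@@H]3C[C@@H](C(=O)O)N(Cc4ccccc4)C3)nn2)c1`, < 10%

In an assay on Sf9 cells for inhibition of histone deacetylase 11 (Homo sapiens), read by fluorescence, tested at 0.5 uM (a higher number here means more inhibition at the concentration tested (going by the name of the read-out), a lower number less inhibition), compound 3 gives < 10%, which is a limit of the assay and not a number. Compound 1 likewise gives < 10%, again a limit. The step that the two limits leave unreadable from compound 1 to compound 3 cannot be read, because of the limit of < 10% in this assay, at which 3 of the 3 values shown sit; the two compounds are mirror images, as the fact that compounds 1 and 3 differ only in the configuration as drawn states, yet no size can be attached to that inversion.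

Compound 4, `O=C(/C=C/c1cn([C@@H]2C[C@@H](C(=O)O)N(Cc3ccccc3)C2)nn1)NO`, differs from compound 3 in one place: 2-(hydroxycarbamoyl)ethenyl in place of 3-(hydroxycarbamoyl)phenyl on an aromatic carbon. Compound 2 carries this same 2-(hydroxycarbamoyl)ethenyl group on the shared core, with an alcohol instead of the acid, and in this assay compound 2 gives < 10%, also a limit. For the measured compounds named here, no measured step bears directly on the change from compound 3 to compound 4; every value shown sits at the limit, so no step of any size has been seen, and none beyond the scatter is expected here.

Compound 4 is therefore expected to give 5%, with a range from 0% to 15%. The estimated step, a step that the limit leaves unreadable from compound 3 to compound 4, is expected to be none beyond the scatter, most likely read again as a limit.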

Compound 4, a percentage reported as inhibition, at one concentration (the size of the read-out at that concentration, not a potency): 12%
Compound 4: the middle estimate sits 7 percentage points below what was measured; the range from low to high includes it.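

In this assay, for the compounds shown here, compound 4 gives 12%, the first value that is a number and not a limit. On an aromatic carbon of the five-membered aromatic ring with 3 nitrogen, 2-(hydroxycarbamoyl)ethenyl in place of 3-(hydroxycarbamoyl)phenyl gives a number at least 2 percentage points higher from compound 3 to compound 4 (that floor lies within the scatter), and carboxy in place of hydroxymethyl on a saturated ring carbon gives a number at least 2 percentage points higher from compound 2 to compound 4 (that floor lies within the scatter). Each step is known only as a floor, so neither change can be called a gain in inhibition, and the true size of both stays unknown because one end of each step is a limit: the limit of < 10% in this assay, at which 3 of the 4 values shown sit.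

The compounds shown leave open whether the mirror image of compound 4 would also give a number in this assay, and whether an amine or a primary amide in place of the carboxy group on the saturated ring carbon would keep the reading of compound 4. They also leave open whether a longer chain carrying the hydroxycarbamoyl group, in place of 2-(hydroxycarbamoyl)ethenyl, would lift the reading beyond the scatter.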